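Tert-butyl to 4-pentylphenyl: outlook for compound 4

The source may report more compounds than this note shows. Statements on the series, on what has been measured and on what is new or still open speak of the compounds shown alone.

Measured compounds:
compound 1 `CC(C)(C)c1cn(C[C@H](O)[C@H]2OC(=O)C(OCc3ccccc3)=C2OCc2ccccc2)nn1` — 29200 nM
compound 2 `O=C1O/C(=C\Cn2cc(-c3cccc(O)c3)nn2)C(OCc2ccccc2)=C1OCc1ccccc1` — 61700 nM
compound 3 `COc1ccccc1-c1cn(C/C=C2\OC(=O)C(OCc3ccccc3)=C2OCc2ccccc2)nn1` — reported only as a limit of the assay, > 100000 nM

In a functional assay on HepG2 cells (Homo sapiens) for antiproliferative activity, read by MTT assay, with a stated time of 72 h (a higher number here means a weaker inhibitor, a lower number a stronger inhibitor), compound 1 gives 29200 nM, the lowest of the two numbers shown. Compound 2 gives 61700 nM, a higher number that lies beyond the scatter. For compound 3 the assay reports only a limit, > 100000 nM; it is not a number. Going by the values given here, the one measured step, an at least 1.6-fold higher number from compound 2 to compound 3 (0.20 log units; that floor lies within the scatter), exchanges one aryl group for another on the five-membered aromatic ring with 3 nitrogen, and its floor is set by the limit (the limit of > 100000 nM in this assay, at which 1 of the 3 values shown sits).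

Compound 4 `CCCCCc1ccc(-c2cn(C[C@H](O)[C@H]3OC(=O)C(OCc4ccccc4)=C3OCc3ccccc3)nn2)cc1` differs from compound 1 by 4-pentylphenyl in place of tert-butyl on an aromatic carbon. Among the compounds with values here, no measured step exchanges tert-butyl for an aryl group, so the measured step between compound 2 and compound 3 does not directly cover this change; it only shows that the aryl groups tried so far sit at or beyond the weaker end of the series. A step of no more than the scatter is therefore expected, with the risk that compound 4 is reported only as a limit. Compound 4 is estimated at 40000 nM, between 12000 nM and 100000 nM, which means an expected step of a 1.4-fold higher number from compound 1 to compound 4 (0.14 log units; within the scatter).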

Compound 4, half-maximal inhibitory concentration: 7460 nM
The estimate for compound 4 lay 5.4-fold (0.73 log units) above the measured number; the whole stated range lies above it.
By their numbers in this assay, from the lowest: compound 4; then compound 1; then compound 2. At a limit, above all of these: compound 3.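

In this assay, the aromatic carbon next to the ring nitrogen accepts 4-pentylphenyl in place of tert-butyl, and the number falls: a 3.9-fold lower number from compound 1 to compound 4 (0.59 log units; beyond the scatter). Going by these compounds alone, this is the first step at this position on the core of compound 1, and it shows that a much larger group, bringing a six-membered aromatic ring of carbon only and no hydrogen-bond donors or acceptors, is compatible with a lower number here; compounds 2 and 3 also carry aryl groups, but each differs from compound 4 in more than one place, so neither enters this reading. Nothing measured in the compounds shown bears on why this step occurs.

On these data alone, it remains open whether the phenyl ring, the pentyl chain or the two together account for the step, a question that plain phenyl and 4-methylphenyl at this position could separate. Also open, as far as these compounds go, is how the number responds to a longer chain such as 4-octylphenyl, or to a chain ending in an amine or a carboxylic acid, on the same core.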